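Dichlorophenyl for phenyl on the cyclohexylguanidine analogue

A few compounds are considered here, and "the series" means these few. Any claim that something is new, unique, unknown or untested is made for them only; others in the source may bear on it.

Measured so far:
compound 1 `c1ccc(C(CCC/N=C(/NCCCc2c[nH]cn2)NC2CCCCC2)c2ccccn2)cc1`, 5.56
compound 2 `N=C(NCCCc1c[nH]cn1)NCCCC(c1ccc(Cl)c(Cl)c1)c1ccccn1`, 7.46

Both numbers come from a functional assay on ileum for antagonist activity at histamine H1 receptor (Cavia porcellus); a lower number here means a less potent compound, a higher number a more potent compound, by a factor of ten per unit of this negative logarithm. Compound 1 stands lowest of the two; compound 2 lies well beyond the scatter above it, but the two differ in more than one place, so no single change can be read from that pair. Compound 3 `Clc1ccc(C(CCC/N=C(/NCCCc2c[nH]cn2)NC2CCCCC2)c2ccccn2)cc1Cl` is not yet measured. It differs from compound 1 in one place: 3,4-dichlorophenyl in place of phenyl on a saturated chain carbon bound to an aromatic carbon and a saturated chain carbon. Compound 3 thereby carries the same 3,4-dichlorophenyl as compound 2 while keeping the cyclohexyl on the guanidine of compound 1. Compound 3 is expected to gain in this assay, a step of a number 1.34 log units higher from compound 1 to compound 3 (beyond the scatter), since compound 2 with the same 3,4-dichlorophenyl gives 7.46. For compound 3 the estimate is 6.9, with a range from 6.2 to 7.6.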

Compound 3, negative logarithm of the antagonist equilibrium constant: 5.76
Beside the measured number, compound 3's estimate is 1.14 log units above it, and the stated range ends above it.
By their numbers in this assay, from the lowest: compounds 1 and 3 (each within the scatter of the next); then compound 2.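

In this assay, with the cyclohexyl on the guanidine kept, 3,4-dichlorophenyl in place of phenyl on a saturated chain carbon bound to an aromatic carbon and a saturated chain carbon gives a number 0.20 log units higher from compound 1 to compound 3 (within the scatter) and so does not separate the two compounds. The high number of compound 2 therefore does not carry over to the cyclohexyl compounds through the 3,4-dichlorophenyl alone: compound 3 gives 5.76 while compound 2, with the same 3,4-dichlorophenyl and no cyclohexyl, gives 7.46. Nothing at hand gives a reason for this result.

Open, on these data alone, is how the numbers run with a methyl or a benzyl on the guanidine in place of cyclohexyl. Also open, as far as these compounds go, is what a single chlorine or a methoxy on the phenyl would give, and what 3,4-dichlorophenyl contributes when the guanidine carries no cyclohexyl.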